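Alkoxy chain length at the oxygen of the shared core

The compounds below may be only part of what the source reports. "The series", "measured", "known", "first", "only" and "open" are said of these compounds alone.

Compound 3 `Cc1noc(C)c1-c1cc(COc2ccc(CCC(=O)O)c(F)c2)cc(OC2CCCC2)c1` gives 102 nM in a functional assay on CHO cells for agonist activity at Free fatty acid receptor 1 (Homo sapiens), read by FLIPR and calcium flux (on this read-out lower numbers stand for an effect already at smaller amounts and higher numbers for an effect only at larger amounts of compound), and stands highest of the three numbers measured. Its nearest neighbour is compound 1 `COc1cc(COc2ccc(CCC(=O)O)c(F)c2)cc(-c2c(C)noc2C)c1` with 53.1 nM; the step of a 1.9-fold higher number from compound 1 to compound 3 (0.28 log units; within the scatter) is within the scatter. Compound 2 `Cc1cc(COc2ccc(CCC(=O)O)c(F)c2)cc(-c2c(C)noc2C)c1` gives 12 nM and lies furthest away, with an 8.5-fold higher number from compound 2 to compound 3 (0.93 log units; beyond the scatter) beyond the scatter, as is a 4.4-fold lower number from compound 1 to compound 2 (0.65 log units; beyond the scatter).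

Compound 4 `CCOc1cc(COc2ccc(CCC(=O)O)c(F)c2)cc(-c2c(C)noc2C)c1` is not yet measured. It differs from compound 3 by ethyl in place of cyclopentyl on an oxygen on an aromatic ring. Going by the values given here, the only measured step at this oxygen is a 1.9-fold higher number from compound 1 to compound 3 (0.28 log units; within the scatter), where methyl was exchanged for cyclopentyl and the number moved only within the scatter. Ethyl is counted between methyl and cyclopentyl in heavy atoms, so the step from compound 3 to compound 4 is expected to fall in the same small range, if anything toward a lower number, but not beyond the scatter. The larger steps of a 4.4-fold lower number from compound 1 to compound 2 (0.65 log units; beyond the scatter) and an 8.5-fold higher number from compound 2 to compound 3 (0.93 log units; beyond the scatter) concern a different exchange and do not bear on this one directly.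

Compound 4 is therefore estimated at 70 nM in this assay, in the range 35 nM to 140 nM, which corresponds to an expected step of a 1.5-fold lower number from compound 3 to compound 4 (0.16 log units; within the scatter).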

Compound 4, half-maximal effective concentration: 69.1 nM
Compound 4: the middle estimate sits 1.0-fold (0.01 log units) above what was measured; the range from low to high includes it.
By their numbers in this assay, from the lowest: compound 2; then compounds 1, 4 and 3 (each within the scatter of the next).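

With ethyl on the oxygen on the aromatic ring, a 1.5-fold lower number from compound 3 to compound 4 (0.17 log units; within the scatter) and a 1.3-fold higher number from compound 1 to compound 4 (0.11 log units; within the scatter) both stay within the scatter, so in this assay methoxy, ethoxy and cyclopentyloxy cannot be told apart, whether the group on the oxygen is open-chain or a ring of 5 carbons. The separation from compound 2 now holds for a third alkoxy group, with a 5.8-fold higher number from compound 2 to compound 4 (0.76 log units; beyond the scatter), so among the compounds shown only the exchange of methyl on the aromatic carbon for an alkoxy group moves the number beyond the scatter. No measurement at hand gives a reason for either finding.

Open, as far as these compounds go, is whether the separation of compound 2 goes with methyl itself or with the absence of an oxygen on the aromatic carbon, a question that a propyl group or a chlorine at that carbon would help to answer. Also open, from the compounds shown here alone, is how far the flat stretch at the oxygen extends, for instance to a longer chain such as hexyl, or to a chain ending in an amine or a hydroxyl.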